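Amide nitrogen substituent: pyrazole replaced by tert-butyl

The compounds below may be only part of what the source reports. "The series", "measured", "known", "first", "only" and "open" are said of these compounds alone.

In an assay on HEK293 cells for agonist activity at transient receptor potential cation channel subfamily M member 8 (Homo sapiens), read by fluorescence and calcium flux, with a stated time of 15 min (on this read-out higher numbers stand for an effect only at larger amounts of compound and lower numbers for an effect already at smaller amounts), compound 1 `Cc1ccc(OCC(=O)N(Cc2cccs2)c2nccs2)cc1` gives 2240 nM and compound 2 `Cc1ccc(OCC(=O)N(Cc2cccs2)c2nccn2C)cc1` gives 1790 nM; the step of a 1.3-fold lower number from compound 1 to compound 2 (0.10 log units; within the scatter) stays within the scatter. Compound 3 `Cc1ccc(OCC(=O)N(Cc2cccs2)c2cn[nH]c2)cc1` gives 1.4 nM in this assay, the lowest of the three numbers, set apart by a 1600-fold lower number from compound 1 to compound 3 (3.20 log units; beyond the scatter) and by a 1300-fold lower number from compound 2 to compound 3 (3.11 log units; beyond the scatter). Compound 4 `Cc1ccc(OCC(=O)N(Cc2cccs2)C(C)(C)C)cc1` carries the change (tert-butyl in place of 1H-pyrazol-4-yl on an amide-type nitrogen). For the measured compounds named here, no measured step removes the ring from this nitrogen, so the expectation rests only on the two steps into compound 3, which show the 1H-pyrazol-4-yl standing far apart from both other groups tried there. A large rise in this assay is therefore expected for compound 4, by about a 1800-fold higher number from compound 3 to compound 4 (3.25 log units; beyond the scatter). Compound 4 is estimated at 2500 nM in this assay, with a range from 300 nM to 20000 nM.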

Compound 4, half-maximal effective concentration: 11000 nM
The estimate for compound 4 lay 4.4-fold (0.64 log units) below the measured number; the range from low to high includes it.
By their numbers in this assay, from the lowest: compound 3; then compounds 2 and 1 (each within the scatter of the next); then compound 4.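

On the amide-type nitrogen, tert-butyl brings a 7900-fold higher number from compound 3 to compound 4 (3.90 log units; beyond the scatter) in this assay, the largest step in the series. The ring-free group also separates from the other two ring groups, with a 6.1-fold higher number from compound 2 to compound 4 (0.79 log units; beyond the scatter) and a 4.9-fold higher number from compound 1 to compound 4 (0.69 log units; beyond the scatter) as modest steps, so compound 4 has the highest number of the four. No evidence is available to explain these differences. Going by these compounds, whether a 1-methyl-1H-pyrazol-4-yl or a phenyl group on this nitrogen would stay close to compound 3 or move towards compounds 1 and 2 remains open.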